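The source may hold more compounds than are shown below. What is called first, only, known or untested is meant among the compounds shown, and "the series" means these compounds.

Compounds measured in a functional assay on A549 cells (Homo sapiens) for cytotoxicity, read by MTT assay, with a stated time of 72 h; a higher number here means a weaker inhibitor, a lower number a stronger inhibitor:
- compound 1 `COc1cc2c(Oc3ccc(NC(=O)c4cn(-c5ccccc5)nn4)cc3F)ccnc2cc1OCCCN1CCCC1`: 360 nM
- compound 2 `COc1cc2c(Oc3ccc(NC(=O)c4cn(-c5ccccc5Cl)nn4)cc3F)ccnc2cc1OCCCN1CCCC1`: 330 nM
- compound 3 `COc1cc2c(Oc3ccc(NC(=O)c4cn(-c5c(C)cccc5C)nn4)cc3F)ccnc2cc1OCCCN1CCCC1`: 1240 nM

Compound 3 gives the highest number of the three, the weakest inhibitor of the set; its steps to the others, a 3.4-fold higher number from compound 1 to compound 3 (0.54 log units; beyond the scatter) and a 3.8-fold higher number from compound 2 to compound 3 (0.57 log units; beyond the scatter), both lie beyond the scatter, whereas a 1.1-fold lower number from compound 1 to compound 2 (0.04 log units; within the scatter) does not.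

Compound 4 `COc1cc2c(Oc3ccc(NC(=O)c4cn(-c5c(C)cccc5C)nn4)cc3F)ccnc2cc1OCCCN1CCN(C)CC1` changes the other end of the molecule: 4-methylpiperazin-1-yl in place of pyrrolidin-1-yl on a saturated chain carbon, three bonds along the chain from an oxygen on an aromatic ring. Among the measured compounds shown here, none of the measured steps touches this part of the structure; all three vary the ring on the aromatic nitrogen only. For the measured compounds named here, there is thus no measured step that bears on the change, and no direction can be read from the data. The expectation is a step of no change at the digits printed from compound 3 to compound 4 (within the scatter) within the scatter. Compound 4 is estimated at 1240 nM, range 600 nM to 2600 nM.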

Compound 4, half-maximal inhibitory concentration: 2180 nM
Beside the measured number, compound 4's estimate is 1.8-fold (0.25 log units) below it, and the stated range covers the measured number.
By their numbers in this assay, from the lowest: compounds 2 and 1 (each within the scatter of the next); then compounds 3 and 4 (each within the scatter of the next).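

Among the compounds shown here, the first measured step at this end of the molecule, a 1.8-fold higher number from compound 3 to compound 4 (0.25 log units; within the scatter), shows that in this assay the 4-methylpiperazin-1-yl group can take the place of pyrrolidin-1-yl on the propyl chain with the difference staying within the scatter. This is so far a single reading, taken only with 2,6-dimethylphenyl on the aromatic nitrogen. Nothing available explains the result.

From the compounds shown here alone, whether the same exchange holds with phenyl or 2-chlorophenyl on that nitrogen remains open. So does the effect of a morpholine ring, a dimethylamino group or a shorter chain at this position.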